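The source may report more compounds than this note shows. Statements on the series, on what has been measured and on what is new or still open speak of the compounds shown alone.

Of the compounds shown here, three sharing one core have been measured in a functional assay on PC-3 cells (Homo sapiens) for inhibition, read by sulforhodamine B assay, with a stated time of 48 h, tested at 10 uM; on this read-out higher numbers stand for more inhibition at the one concentration tested (going by the name of the read-out) and lower numbers for less inhibition. Compound 1, `c1ccc(-c2cn3ccnc3c(-c3ccc4ncn(C5CCCCC5)c4c3)n2)cc1`, gives 92%. Compound 2, `c1ccc2c(-c3cn4ccnc4c(-c4ccc5ncn(C6CCCCC6)c5c4)n3)cccc2c1`, gives 36.5%. Compound 3, `Fc1ccc(-c2cn3ccnc3c(-c3ccc4ncn(C5CCCCC5)c4c3)n2)cc1`, gives 53.6%, which places it second highest of the three: compound 2 sits a number 17.1 percentage points higher from compound 2 to compound 3 (beyond the scatter), while compound 1 stands above it by a number 38.4 percentage points lower from compound 1 to compound 3 (beyond the scatter).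

Compound 4, `c1cn2cc(-c3ccsc3)nc(-c3ccc4ncn(C5CCCCC5)c4c3)c2n1`, has not yet been measured. It differs from compound 3 in one place: thiophen-3-yl in place of 4-fluorophenyl on an aromatic carbon.

Every measured step here changes the same aryl group on the core, so all three bear on this one. Exchanging phenyl for naphthalen-1-yl gave a number 55.5 percentage points lower from compound 1 to compound 2 (beyond the scatter), a large drop; putting fluoro on phenyl gave a number 38.4 percentage points lower from compound 1 to compound 3 (beyond the scatter), also large; and going from naphthalen-1-yl to 4-fluorophenyl gave a number 17.1 percentage points higher from compound 2 to compound 3 (beyond the scatter), a modest rise. Compound 1, with unsubstituted phenyl, gives the highest number of the three, and the smaller groups gave higher numbers than the largest. Thiophen-3-yl is smaller still than 4-fluorophenyl and carries no fluoro, so compound 4 is expected to land above compound 3, by an estimated a number 14.4 percentage points higher from compound 3 to compound 4 (beyond the scatter). Compound 4 is therefore estimated at 68%, with a likely range from 40% to 92%.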

Compound 4, a percentage reported as inhibition, at one concentration (the size of the read-out at that concentration, not a potency): 19.9%
Compound 4: middle estimate off by 48.1 percentage points, on the high side; the measured number lies below the stated range.
By their numbers in this assay, from the lowest: compound 4; then compound 2; then compound 3; then compound 1.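

In this assay, replacing 4-fluorophenyl with thiophen-3-yl gives a number 33.7 percentage points lower from compound 3 to compound 4 (beyond the scatter) and thus the lowest number of the four; the same group also falls short of naphthalen-1-yl, with a number 16.6 percentage points lower from compound 2 to compound 4 (beyond the scatter), and of unsubstituted phenyl, with a number 72.1 percentage points lower from compound 1 to compound 4 (beyond the scatter). Until now, the largest group gave the lowest number, but this smaller five-membered ring with one hetero atom goes lower still, so across these four compounds the numbers do not simply rise as the group gets smaller: compound 2 and compound 4 both lie at the low end, despite carrying the largest and the smallest groups. Nothing available explains why thiophen-3-yl gives this result at this position.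

From the compounds shown here alone, it remains open whether the low number of compound 4 goes with the sulfur atom or with the five-membered ring, a question that furan-3-yl or pyridin-3-yl at the same place could help to separate. Within the data shown here, also open is whether any group on the phenyl ring, such as methoxy or chloro, could keep the number as high as in compound 1, given that the only such group here is fluoro.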